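A few compounds are considered here, and "the series" means these few. Any claim that something is new, unique, unknown or untested is made for them only; others in the source may bear on it.

Measured in an ADME assay on A549 cells (Homo sapiens) for cytotoxicity, read by resazurin assay, with a stated time of 48 h; a lower number here means that less compound is tolerated, a higher number that more compound is tolerated:
compound 1 `CCCCCCCCC(C)Nc1ccc(NC(=O)c2cc(Cl)ccc2O)c(Cl)c1` gives 21900 nM
compound 2 `O=C(Nc1ccc(N(CC2CC2)CC2CC2)cc1Cl)c1cc(Cl)ccc1O` gives 12800 nM
compound 3 `O=C(Nc1ccc(NCc2ccc3cn[nH]c3c2)cc1Cl)c1cc(Cl)ccc1O` gives 45300 nM

Among these three, compound 2 gives the lowest number in this assay; compound 1 sits within the scatter of it, while compound 3 lies beyond the scatter. No two of the measured compounds differ in only one place, so no single change has yet been tied to a shift in this assay.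

Compound 4 `O=C(Nc1ccc(N(CCCO)CCCO)cc1Cl)c1cc(Cl)ccc1O` has not been measured. It differs from compound 2 by bis(3-hydroxypropyl)amino in place of bis(cyclopropylmethyl)amino on an aromatic carbon. Within the data shown here, with no matched pair to lean on, the expectation is a modest step upward in this assay, though one that may not clear the scatter. Compound 4 is therefore estimated at 30000 nM, in a range from 12000 nM to 80000 nM, which means an expected step of a 2.3-fold higher number from compound 2 to compound 4 (0.37 log units; beyond the scatter).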

Compound 4, half-maximal cytotoxic concentration: 114000 nM
Estimate against measurement, compound 4: 3.8-fold (0.58 log units) below; measured number above the stated range.
By their numbers in this assay, from the lowest: compounds 2 and 1 (each within the scatter of the next); then compound 3; then compound 4.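

In this assay, among these compounds, a single change can now be read for the first time: on an aromatic carbon para to a large group, bis(3-hydroxypropyl)amino in place of bis(cyclopropylmethyl)amino brings an 8.9-fold higher number from compound 2 to compound 4 (0.95 log units; beyond the scatter) and so a shift beyond the scatter. This position therefore responds to what it carries, even when both groups hold the same number of heavy atoms. Nothing measured here accounts for the shift.

On these data alone, this change removes the rings and adds the hydroxyl groups together, so their separate shares stay unknown. As far as these compounds go, a dipropylamino group at this position would help tell them apart, and whether it would fall nearer compound 2 or compound 4 remains open.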